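The source may report more compounds than this note shows. Statements on the series, on what has been measured and on what is new or still open speak of the compounds shown alone.

Compound 1 `CCC(C)(C)Cc1c[nH]c(CCc2ccc(-c3cnccn3)cc2)n1`, compound 2 `CCC(C)(C)Cc1c[nH]c(CCc2ccc(-c3cnsc3)cc2)n1` and compound 3 `CCC(C)(C)Cc1c[nH]c(CCc2ccc(-n3ccnn3)cc2)n1` share one core and differ only in the five-membered ring at its far end. In a functional assay on HEK293 cells for agonist activity at Bombesin receptor subtype-3 (Mus musculus), read by luminescence and calcium flux, with a stated time of 10 min (a lower number here means that less compound is needed, a higher number that more compound is needed for the effect), compound 1 gives 107 nM, compound 2 gives 119 nM and compound 3 gives 111 nM; all three lie within the scatter of one another, so compound 3 stands neither apart from nor ahead of the others. Compound 4 `CCC(C)(C)Cc1c[nH]c(CCc2ccc(-c3ccns3)cc2)n1` carries the change (1,2-thiazol-5-yl in place of 1H-1,2,3-triazol-1-yl on an aromatic carbon). Every exchange of such a ring seen so far stayed within the scatter: a 1.1-fold higher number from compound 1 to compound 2 (0.05 log units; within the scatter), a 1.0-fold higher number from compound 1 to compound 3 (0.02 log units; within the scatter) and a 1.1-fold lower number from compound 2 to compound 3 (0.03 log units; within the scatter). A further swap of a five-membered ring at the same place is therefore expected to give no step beyond the scatter in this assay, so compound 4 is estimated at 115 nM (range 60 nM to 230 nM), meaning an expected step of a 1.0-fold higher number from compound 3 to compound 4 (0.02 log units; within the scatter).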

Compound 4, half-maximal effective concentration: 103 nM
The estimate for compound 4 lay 1.1-fold (0.05 log units) above the measured number; low and high end bracket the measured number.
By their numbers in this assay, from the lowest: compounds 4, 1, 3 and 2 (each within the scatter of the next).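

Putting 1,2-thiazol-5-yl in place of 1,2-thiazol-4-yl, the same ring joined through a different carbon, leaves the result in this assay within the scatter (a 1.2-fold lower number from compound 2 to compound 4 (0.06 log units; within the scatter)). The exchanges for 1H-1,2,3-triazol-1-yl (a 1.1-fold lower number from compound 3 to compound 4 (0.03 log units; within the scatter)) and for pyrazin-2-yl (a 1.0-fold lower number from compound 1 to compound 4 (0.02 log units; within the scatter)) do the same, so these four aromatic rings cannot be told apart here, whatever their hetero atoms. No evidence is available to explain this sameness. Still open, on these data alone, is whether a non-ring group at this place, such as an amine or a carboxylic acid, would produce a step beyond the scatter.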